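The compounds below may be only part of what the source reports. "The series", "measured", "known", "first", "only" and "open" are said of these compounds alone.

Measured compounds and their values in this study:

Compound 1, `NC(=O)/C=C1\CCc2c(Cl)cccc21`: 67%
Compound 2, `CCNC(=O)/C=C1\CCc2c(F)cc(F)cc21`: 67%
Compound 3, `NC(=O)/C=C1\CCc2c1ccc(F)c2F`: 100%

In a functional assay on the whole organism with Mus musculus as the target, at a dose of 100 mg/kg by the intraperitoneal route (on this read-out lower numbers stand for less inhibition and higher numbers for more inhibition at the one dose given (going by the name of the read-out)), compound 1 gives 67%. Compound 2 gives 67% in this assay, so the two stand level at the digits shown, within the scatter, and together they are the lowest of the three numbers. Compound 3 gives 100%, a reading well above compound 1 and beyond the scatter. Going by the values given here, no pair among the measured compounds differs in one place only, so no single step can be read from them.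

The compound still to be measured is compound 4, `O=C(/C=C1\CCc2c(Cl)cccc21)NC1CC1`. Against compound 1 the change is cyclopropyl in place of hydrogen on an amide-type nitrogen. Among the compounds with values here, the one measured compound that also carries a group on the amide-type nitrogen, compound 2, shows the same value as compound 1, but the two differ in their ring substitution as well, so their values alone do not tell what the nitrogen group does.

Within the data shown here, with no step to rest on, compound 4 is expected to stay close to compound 1 in this assay, and the step of a number 2 percentage points lower from compound 1 to compound 4 (within the scatter) is estimated to lie within the scatter. The estimate for compound 4 is 65%, with a range from 40% to 90%.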

Compound 4, a percentage reported as inhibition, in the whole organism at one dose (the size of the read-out at that dose, not a potency): 100%
Compound 4: middle estimate off by 35 percentage points, on the low side; the whole stated range lies below it.
By their numbers in this assay, from the lowest: compounds 1 and 2 (each within the scatter of the next); then compounds 3 and 4 (each within the scatter of the next).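

Putting cyclopropyl in place of hydrogen on the amide-type nitrogen gives a number 33 percentage points higher from compound 1 to compound 4 (beyond the scatter) in this assay, and this is the only single change among the compounds shown that can be read on its own. Compound 2 also carries a group on this nitrogen but differs from compound 1 in its ring substitution as well, whereas this pair shows that a change at the nitrogen alone, with the core of compound 1 held constant, can move the read-out well beyond the scatter. No measurement at hand bears on why the step has this size.

The compounds shown leave open whether the step belongs to cyclopropyl in particular or would also appear with another group on this nitrogen, such as ethyl, cyclobutyl or a longer chain on the core of compound 1. They also leave open what cyclopropyl would do on the core of compound 3, and what a second group on the same nitrogen, such as a further methyl, would do.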